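This account rests on a few compounds, and the source may have more. Where it says the series, first, only, none or still open, it means among the compounds named here.

Measured compounds:
compound 1 `CO[C@]1(c2ccc(OCc3c(-c4c(Cl)cccc4Cl)noc3C3CC3)cc2Cl)C[C@H](c2cccc(C(=O)O)c2)C1`: 75%
compound 2 `O=C(O)c1ccc(C2CC2c2ccc(OCc3c(-c4c(Cl)cccc4Cl)noc3C3CC3)cc2Cl)cn1`: 68%
compound 3 `CC(C)n1nc(C(=O)O)cc1[C@@H]1C[C@H]1c1ccc(OCc2c(-c3c(Cl)cccc3Cl)noc2C2CC2)cc1Cl`: 79%

In an assay on HEK293 cells for agonist activity at Bile acid receptor (Homo sapiens) (a higher number here means a larger maximal response, a lower number a smaller maximal response), compound 1 gives 75%, the second highest of the three numbers. Its nearest neighbour is compound 3, which gives 79%, and the furthest is compound 2, which gives 68%; both of these differences lie within the usual scatter of repeated measurements, so no order among the three can be read from the numbers. The three measured compounds carry different linkers and different acid-bearing rings, yet all reach a similar maximal response.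

Compound 4 `O=C(O)c1cccc([C@H]2C[C@@H](c3ccc(OCc4c(-c5c(Cl)cccc5Cl)noc4C4CC4)cc3Cl)C2)c1` differs from compound 1 in one place: hydrogen in place of methoxy on a saturated ring carbon. No pair of measured compounds isolates this change, so its effect cannot be read from a shown step. Given that compound 1, compound 2 and compound 3 all fall within the scatter of one another despite larger differences in structure, the step expected in this assay from compound 1 to compound 4 is none beyond the scatter. Compound 4 is therefore estimated to give 75% in this assay, with a range from 62% to 88%. That estimate means a step of no change at the digits printed from compound 1 to compound 4 (within the scatter), which is expected to stay within the scatter.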

Compound 4, largest response reached (reported as efficacy), in percent of the reference or control that the assay uses: 88%
Estimate against measurement, compound 4: 13 percentage points below; low and high end bracket the measured number.
By their numbers in this assay, from the lowest: compounds 2, 1, 3 and 4 (each within the scatter of the next, the first and the last beyond it).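

Among these compounds, the pair of compound 1 and compound 4 gives the first reading of a single change at this position: in this assay, hydrogen in place of methoxy on a saturated ring carbon of the four-membered ring, two ring bonds from the ring atom that bears the 3-carboxyphenyl group, goes with a number 13 percentage points higher from compound 1 to compound 4 (beyond the scatter), a modest step. The earlier compounds shown here differ from one another in more than one place, so they could not show that this carbon alone can shift the maximal response, nor that the methoxy group is dispensable for a high response on this scaffold. No measurement shown here accounts for the size or direction of this step.

At this carbon the compounds shown carry only methoxy or hydrogen, so it remains open where a hydroxyl group, a fluorine atom or a longer ether chain such as ethoxy would fall relative to compound 1 and compound 4. As far as these compounds go, compound 2 and compound 3 have a different linker and another acid-bearing ring, and it also remains open whether a methoxy group added to their linkers would be followed by a comparable step.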